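The source may report more compounds than this note shows. Statements on the series, on what has been measured and on what is new or still open speak of the compounds shown alone.

Measured in a functional assay on OVCAR-3 cells (Homo sapiens); on this read-out higher numbers stand for weaker inhibition of growth and lower numbers for stronger inhibition of growth:
- compound 1 `Cc1cc(C)c2c(O)cc(-c3ccc(Cl)cc3)nc2n1` gives 18200 nM
- compound 2 `Oc1cc(-c2ccc(Cl)cc2)nc2ncccc12` gives 23400 nM
- compound 3 `Cc1ccnc2nc(-c3ccc(F)cc3)cc(O)c12` gives 56200 nM

Compound 3 at 56200 nM holds the highest number of the three, so it shows the weakest inhibition of growth in this assay here. Its gaps to compound 2 and to compound 1 both lie beyond the scatter.

The next compound is compound 4 `Cc1ccnc2nc(-c3ccc(Cl)cc3)cc(O)c12` and it carries chloro in place of fluoro on an aromatic carbon, para to a large group (chloro in place of fluoro on an aromatic carbon). Among the measured compounds shown here, no measured pair differs in one place only, so the size of this exchange has not been seen directly.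

For the measured compounds named here, the only guide is indirect. Compound 2 at 23400 nM and compound 1 at 18200 nM both carry chloro in that place, and these two values lie within the scatter of each other even though their cores differ in methyl groups. Going by the values given here, compound 3 is the only fluoro compound measured, so this comparison is thin.

A move toward those two values is expected, and the estimated change is a 2.3-fold lower number from compound 3 to compound 4 (0.37 log units; beyond the scatter) toward stronger inhibition of growth, a modest step just beyond the scatter. For compound 4 the estimate is 24000 nM with an expected range from 11000 nM to 50000 nM in this assay once measured.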

Compound 4, concentration for 50% growth inhibition: 3160 nM
Beside the measured number, compound 4's estimate is 7.6-fold (0.88 log units) above it; the whole stated range lies above it.
By their numbers in this assay, from the lowest: compound 4; then compounds 1 and 2 (each within the scatter of the next); then compound 3.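

In this assay, among the compounds shown here, chloro in place of fluoro on the aromatic carbon para to a large group gives the largest step so far (an 18-fold lower number from compound 3 to compound 4 (1.25 log units; beyond the scatter)), so on the core shared by these two compounds the result depends strongly on which halogen sits at this place. With chloro held constant, the methyl steps are also beyond the scatter, one adding a methyl on an aromatic carbon (a 7.4-fold lower number from compound 2 to compound 4 (0.87 log units; beyond the scatter)) and the other removing one (a 5.8-fold lower number from compound 1 to compound 4 (0.76 log units; beyond the scatter)), so compound 4 has a lower number than either neighbour and the methyl pattern matters in a way the close values of compound 1 and compound 2 gave no sign of. No measurement at hand accounts for any of these steps.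

On these data alone, whether the chloro-for-fluoro step keeps its size on the cores of compound 1 and compound 2 stays open. Also open, as far as these compounds go, is how bromo, methoxy or a nitrile at the same place would compare with chloro, and whether an ethyl group could stand in for the methyl on the core of compound 4.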